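The source may hold more compounds than are shown below. What is called first, only, known or untested is meant among the compounds shown, and "the series" means these compounds.

Of the compounds shown here, two with a shared core have been tested in an ADME assay on PANC-1 cells (Homo sapiens) for inhibition, read by MTT assay, with a stated time of 90 h; on this read-out lower numbers stand for stronger inhibition of growth and higher numbers for weaker inhibition of growth. Compound 1 `Cc1ccc2oc(-c3cc4ccccc4s3)cc(=O)c2c1` gives 12.9 ug/mL in this assay. Compound 2 `O=C(CC(=O)c1ccccc1O)c1cc2ccccc2s1` gives 7.77 ug/mL in this assay, a number that differs from that of compound 1 by less than the usual scatter, so the two compounds cannot be set apart on these data. Compound 3 `O=C(CC(=O)c1cc(Cl)ccc1O)c1cc2ccccc2s1` has not yet been measured; it differs from compound 2 by chloro in place of hydrogen on an aromatic carbon. Within the data shown here, no pair of measured compounds shows a step of this kind, so there is nothing in the data to say how such a change moves the number; the step from compound 2 to compound 3 is therefore expected to stay within the scatter, in either direction. For compound 3 the estimated step is a 1.1-fold lower number from compound 2 to compound 3 (0.05 log units; within the scatter). The value expected for compound 3 in this assay is 7 ug/mL, with a range from 3.5 ug/mL to 14 ug/mL.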

Compound 3, concentration for 50% growth inhibition: 8.44 ug/mL
For compound 3 the middle estimate is 1.2-fold (0.08 log units) below the measured one; the measured number falls inside the stated range.
By their numbers in this assay, from the lowest: compounds 2, 3 and 1 (each within the scatter of the next).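

Across a 1.1-fold higher number from compound 2 to compound 3 (0.04 log units; within the scatter) in this assay, chloro in place of hydrogen on an aromatic carbon, para to a hydroxy group and meta to a large group, leaves compound 3 not set apart from compound 2. This is the only step of its kind among the compounds shown, and it gives the first reading for this position: here, chloro does not move the number beyond the scatter. Nothing in the data shown accounts for this result.

Going by these compounds, whether a different group at this position, such as an amine, a methoxy group or a carboxylic acid, would move the number beyond the scatter remains open. Also open, on these data alone, is whether chloro would do the same on another carbon of this ring or on the core of compound 1.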